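The compounds below may be only part of what the source reports. "The series", "measured", "known", "first", "only" and "open" are said of these compounds alone.

The three measured compounds, with their results in an assay on isolated protein for inhibition of DNA topoisomerase 1 (Homo sapiens), with a stated time of 30 min, tested at 100 uM; a higher number here means a stronger effect of the compound at the concentration tested, a lower number a weaker effect:

Compound 1 `Oc1ccc(-c2cc(-c3cccs3)nc(-c3ccccc3Cl)c2)cc1` gives 2.2%.
Compound 2 `Oc1cccc(-c2cc(-c3cccs3)nc(-c3ccccc3Cl)c2)c1` gives 2.7%.
Compound 3 `Oc1cccc(-c2cc(-c3ccccc3)nc(-c3ccc(Cl)cc3)c2)c1` gives 7.1%.

Compound 4 `Oc1ccc(-c2cc(-c3ccccc3)nc(-c3ccc(Cl)cc3)c2)cc1` has not yet been measured in this assay. It arises from compound 3 by a single change: 4-hydroxyphenyl in place of 3-hydroxyphenyl on an aromatic carbon. The same kind of change has already been made once among the measured compounds, from compound 2 to compound 1: 4-hydroxyphenyl in place of 3-hydroxyphenyl on an aromatic carbon. The surroundings of the place are not identical in the two pairs: in compound 2 the place is meta to a 2-chlorophenyl group and meta to a thiophen-2-yl group, whereas in compound 3 it is meta to a 4-chlorophenyl group and meta to a phenyl group. How the two cores differ beyond that is not broken down here. The earlier step was small: a number 0.5 percentage points lower from compound 2 to compound 1 (within the scatter). Among the measured compounds shown here, all three measured numbers lie within the usual scatter of one another, so none of the three can be called stronger or weaker than the others, and the one measured step gives no sign that this change shifts the read-out. On that footing the step from compound 3 to compound 4 is expected to be about as small, a number 1.1 percentage points lower from compound 3 to compound 4 (within the scatter), because a number 0.5 percentage points lower from compound 2 to compound 1 (within the scatter) stayed within the scatter. For compound 4 the estimate in this assay is 6%, with a likely range from 0% to 15%.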

Compound 4, a percentage reported as inhibition, at one concentration (the size of the read-out at that concentration, not a potency): 68%
For compound 4 the middle estimate is 62 percentage points below the measured one; measured number above the stated range.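

In this assay, the same swap of 3-hydroxyphenyl for 4-hydroxyphenyl behaves very differently on the two cores, and on the core of compound 3 it gives a number 60.9 percentage points higher from compound 3 to compound 4 (beyond the scatter). The two results do not match: the same change on two cores in this assay, a number 0.5 percentage points lower (within the scatter) from compound 2 to compound 1 and a number 60.9 percentage points higher (beyond the scatter) from compound 3 to compound 4, 61.4 percentage points apart, beyond the scatter of two such steps
So in this series, the outcome of this change on one core was no guide to its outcome on the other, and the change cannot be treated as having one fixed effect wherever it is made. Among the compounds shown here, this does not show which difference between the cores matters, whether the 2-chlorophenyl group against the 4-chlorophenyl group or the thiophen-2-yl group against the phenyl group, and each core offers only a single pair, so no general rule can be drawn from them.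

The compounds shown leave open what happens to this swap on a core that mixes these features, such as one carrying the 4-chlorophenyl group together with the thiophen-2-yl group. They also leave open whether the hydroxyl group itself is needed on the core of compound 4, which could be tested by putting a methoxy group, an amine or a carboxylic acid in its place.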